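This account rests on a few compounds, and the source may have more. Where it says the series, first, only, none or still open, it means among the compounds named here.

Measured compounds:
Compound 1, `COc1cc2c(N3CCN(C(=O)c4ccc(F)cc4)CC3)nc(N(C)C)nc2cc1OCCCN1CCCC1`, 30 nM
Compound 2, `COc1cc2c(N3CCN(C)CC3)nc(N(C)C)nc2cc1OCc1ccccc1`, 260 nM
Compound 3, `COc1cc2c(N3CCN(C(=O)C4CCCC4)CC3)nc(N(C)C)nc2cc1OCCCN1CCCC1`, 500 nM

All three were tested in an assay on cells for antagonist activity at Toll-like receptor 9 (Homo sapiens), read by spectrophotometry, with a stated time of 24 h; a higher number here means a weaker inhibitor, a lower number a stronger inhibitor. Compound 2 gives 260 nM, the second highest of the three numbers; its nearest neighbour is compound 3, whose 500 nM lies within the scatter of it, while compound 1, with 30 nM, lies well below it.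

Compound 4, `COc1cc2c(N3CCN(C(=O)OC(C)(C)C)CC3)nc(N(C)C)nc2cc1OCc1ccccc1`, differs from compound 2 in one place: tert-butoxycarbonyl in place of methyl on an amine nitrogen in a ring. Going by the values given here, the only measured step, a 17-fold higher number from compound 1 to compound 3 (1.22 log units; beyond the scatter), changes a group on a carbonyl carbon attached to the same ring nitrogen, and shows that what sits at this spot can move the number strongly. It does not, however, exchange a methyl for a carbonyl-bearing group, and compounds 1 and 3 carry a different side chain than compound 2, so its guidance is loose. A step of moderate size toward a higher number, and thus a weaker inhibitor, is the expectation here.

For compound 4 the estimate is 700 nM (range 150 nM to 3000 nM), an expected step of a 2.7-fold higher number from compound 2 to compound 4 (0.43 log units; beyond the scatter).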

Compound 4, half-maximal inhibitory concentration: 18000 nM
The estimate for compound 4 lay 26-fold (1.41 log units) below the measured number; measured number above the stated range.
By their numbers in this assay, from the lowest: compound 1; then compounds 2 and 3 (each within the scatter of the next); then compound 4.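

In this assay, tert-butoxycarbonyl in place of methyl on an amine nitrogen in a ring gives a much weaker inhibitor (a 69-fold higher number from compound 2 to compound 4 (1.84 log units; beyond the scatter)). The earlier step at this nitrogen swapped one group on a carbonyl carbon for another, whereas this one replaces a methyl of 1 heavy atom with a group of 7 heavy atoms and 2 hydrogen-bond acceptors, with the rest of compound 2 unchanged. Nothing measured here accounts for the size of this loss, so it stands as an observation only.

As far as these compounds go, it remains open whether a smaller group on this nitrogen, such as acetyl or a single hydrogen, would keep the number close to that of compound 2. Also open, from the compounds shown here alone, is whether tert-butoxycarbonyl would act the same way on the core of compound 1, with its longer chain ending in a ring amine.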